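The compounds below may be only part of what the source reports. "The series", "measured", "known", "first", "only" and "open" are said of these compounds alone.

Two closely related compounds have been measured in a functional assay on cells (Leukemia cell, Homo sapiens) for inhibition, with a stated time of 48 h; a lower number here means a stronger inhibitor of growth, a higher number a weaker inhibitor of growth. Compound 1 `O=C(Nc1sc2c(c1C(=O)NNc1ccccc1)CCCCC2)NS(=O)(=O)c1ccccc1` gives 18600 nM. Compound 2 `O=C(Nc1sc2c(c1C(=O)NNc1ccc(Cl)cc1)CCCCC2)NS(=O)(=O)c1ccccc1`, which carries a chloro group in place of a hydrogen on an aromatic carbon, gives 30600 nM. Among the measured compounds shown here, the only step between measured compounds, a 1.6-fold higher number from compound 1 to compound 2 (0.22 log units; within the scatter), shows that this change made no difference beyond the scatter. Of the two numbers, compound 2 has the higher one, though its gap to compound 1 is within the scatter.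

Compound 3 `CCCNC(=O)c1c(NC(=O)NS(=O)(=O)c2ccccc2)sc2c1CCCCC2` keeps the shared core and the sulfonylurea side, but differs from compound 2 in one place: propyl in place of (4-chlorophenyl)amino on an amide-type nitrogen. For the measured compounds named here, no measured step touches this part of the molecule, so the single step seen, from a chloro to a hydrogen on the aromatic ring, says nothing about it. With no guide, the expectation for compound 3 is a number near that of compound 2, and the estimated step of a 1.0-fold lower number from compound 2 to compound 3 (0.01 log units; within the scatter) is taken as none beyond the scatter, with a wide range to reflect the lack of information. Compound 3 is therefore estimated at 30000 nM, with a range from 8000 nM to 120000 nM.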

Compound 3, concentration for 50% growth inhibition: 42200 nM
Beside the measured number, compound 3's estimate is 1.4-fold (0.15 log units) below it; the measured number falls inside the stated range.
By their numbers in this assay, from the lowest: compounds 1, 2 and 3 (each within the scatter of the next, the first and the last beyond it).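

Among the compounds shown here, this is the first look at the amide-type nitrogen, and in this assay the change there is large in structure: the whole (4-chlorophenyl)amino group, aromatic ring included, gives way to a plain propyl chain. Yet the outcome is small, with a 1.4-fold higher number from compound 2 to compound 3 (0.14 log units; within the scatter) when the chloro compound is the starting point and a 2.3-fold higher number from compound 1 to compound 3 (0.36 log units; beyond the scatter) when the starting point is the compound with anilino on that nitrogen, so only the second step lies beyond the scatter, and then only modestly. The aromatic ring is therefore not required for growth inhibition at this level in these compounds, and nothing available explains why the numbers move so little.

This change removes the ring and the amino nitrogen together, so their separate contributions stay unresolved, and a benzyl group on the amide-type nitrogen would keep the ring without that amino nitrogen. On these data alone, it is also open how a longer chain such as hexyl, or a propyl chain ending in an amine or a carboxylic acid, would compare with propyl at this position.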